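This account rests on a few compounds, and the source may have more. Where it says the series, first, only, none or still open, it means among the compounds named here.

Compound 3 `CCCCOc1ccc(-c2nc3ncccn3c2NC(C)C)cc1` holds the higher of the two numbers in a toxicity assay on A549 cells (Homo sapiens) for cytotoxicity, read by luminescence and CellTiter-Glo, with a stated time of 48 h (on this read-out lower numbers stand for higher toxicity in this test and higher numbers for lower toxicity in this test), at 68000 nM. Its nearest neighbour, compound 1 `CCCCOc1ccc(-c2nc3ncccn3c2NC2CCCC2)cc1`, gives 40000 nM in this assay. The gap between them is a 1.7-fold higher number from compound 1 to compound 3 (0.23 log units; within the scatter). For compound 2 `CCCCOc1ccc(-c2nc3ncccn3c2NCCC)cc1` this assay records only a limit, > 100000 nM. Compound 4 `CCCCOc1ccc(-c2nc3ncccn3c2NCC2CC2)cc1` is compound 3 with cyclopropylmethyl in place of isopropyl on a nitrogen on an aromatic ring. Among the compounds with values here, three measured steps bear on this position: an at least 2.5-fold higher number from compound 1 to compound 2 (0.39 log units; beyond the scatter), a 1.7-fold higher number from compound 1 to compound 3 (0.23 log units; within the scatter) and an at least 1.4-fold lower number from compound 2 to compound 3 (0.16 log units; that floor lies within the scatter); only the first is beyond the scatter, and it ends at the limit of > 100000 nM in this assay, at which 1 of the 3 values shown sits. Among these small alkyl groups the swap is therefore expected to produce no step beyond the scatter, a 1.1-fold lower number from compound 3 to compound 4 (0.05 log units; within the scatter). For compound 4 a value of 60000 nM is estimated in this assay, between 25000 nM and 150000 nM.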

Compound 4, half-maximal cytotoxic concentration: > 100000 nM
Compound 4 was reported as a limit; the forecaster's own chance of this, stated with the estimate: 30%; middle value at least 1.6-fold (0.22 log units) from the limit.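

Compound 4 is recorded only as a limit in this assay, and read as such, cyclopropylmethyl gives an at least 1.4-fold higher number from compound 3 to compound 4 (0.16 log units; that floor lies within the scatter) and an at least 2.5-fold higher number from compound 1 to compound 4 (0.39 log units; beyond the scatter) with only the second beyond the scatter. Cyclopentyl now stands apart from both propyl and cyclopropylmethyl by steps beyond the scatter, while isopropyl is not separated from any of the three. The step from compound 2 to compound 4 cannot be read, and the top of the series is now crowded: the limit of > 100000 nM in this assay, at which 2 of the 4 values shown sit.

From the compounds shown here alone, how far compound 2 and compound 4 lie past that limit stays open. So does whether a longer chain, or an alkyl group carrying an amine or a carboxylic acid, on that nitrogen would give a lower number or stay at the limit.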